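A Third Compound Against an Unbroken Limit

This account rests on a few compounds, and the source may have more. Where it says the series, first, only, none or still open, it means among the compounds named here.

In an ADME assay on HEK293 cells (Homo sapiens) for cytotoxicity, read by luminescence, with a stated time of 72 h (on this read-out lower numbers stand for an effect already at smaller amounts and higher numbers for an effect only at larger amounts of compound), compound 1 `CCOC(=O)c1c(-c2cccc(OC)c2)[nH]c2cc(C(F)(F)F)ccc2c1=O` gives > 22000 nM as a limit of the assay and not as a number. Compound 2 `CCOC(=O)c1c(-c2cccc(OC(F)(F)F)c2)[nH]c2cc(C(F)(F)F)ccc2c1=O` stands at > 22000 nM and this too is only a limit. Together the two compounds make up the limit of > 22000 nM in this assay, at which 2 of the 2 values shown sit, and neither has a numerical reading. Within the data shown here, the one measured step is a step that the two limits leave unreadable from compound 1 to compound 2 and it concerns trifluoromethyl in place of methyl on an oxygen on an aromatic ring. That step offers no size to carry forward.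

Compound 3 `CCOC(=O)c1c(-c2cccc(Cl)c2)[nH]c2cc(C(F)(F)F)ccc2c1=O` has chloro in place of trifluoromethoxy on an aromatic carbon, meta to a large group, and chloro in place of trifluoromethoxy on an aromatic carbon gives the count of what changes. Since compound 2 reads > 22000 nM as a limit, no step beyond the usual scatter is expected in this assay and no direction can be named. The expected step is a step that the limit leaves unreadable from compound 2 to compound 3 and it remains an estimate. For compound 3 the estimated value is 25000 nM with an expected range from 12000 nM to 40000 nM and the assay may well report only a limit again.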

Compound 3, half-maximal effective concentration: > 22000 nM
Compound 3: no number, only a limit (the forecaster's own chance of this, stated with the estimate: 75%); the middle value does not contradict the limit.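

In this assay no step can be read from compound 2 to compound 3 or from compound 1 to compound 3, as all three compounds give only a limit of the assay and not a number: the limit of > 22000 nM in this assay, at which 3 of the 3 values shown sit.

The compounds shown leave open at what concentration any of the three would show an effect, and whether methoxy, trifluoromethoxy and chloro differ at all.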